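A few compounds are considered here, and "the series" means these few. Any claim that something is new, unique, unknown or untested is made for them only; others in the source may bear on it.

Compound 1, shown as `CN1C[C@H]2C=C(c3cccnc3)C[C@H](C2)C1`, was tested in an in vitro functional assay on SH-EP1 cells for agonist activity at Neuronal acetylcholine receptor; alpha4/beta2 (Homo sapiens), read by FLIPR and calcium flux (a lower number here means a smaller maximal response, a higher number a larger maximal response), where compound 1 gives 19%. That is the lower of the two numbers available. The other measured compound, compound 2, has the structure `COc1ccc(C2=CC3CC(C2)CN(C)C3)cn1`; in this assay compound 2 gives 91%, a number far higher than that of compound 1, and this gap lies well beyond the usual scatter. Among the compounds with values here, no single-point step between the two measured compounds is available, so their values can only be set side by side.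

The unmeasured compound 3 has the structure `CN1C[C@@H]2C=C(c3cccnc3)C[C@@H](C2)C1`. Its relation to compound 1 is this: the two compounds have the same atoms and bonds and differ only in configuration as drawn: 2 of 2 stereo elements differ (all stereocentres are inverted: mirror images); a stereocentre at a saturated ring carbon is drawn R in compound 1 and S in compound 3; a stereocentre at a saturated ring carbon is drawn S in compound 1 and R in compound 3. The two compounds are thus mirror images of one another.

Within the data shown here, with only two measured numbers and no mirror-image pair among them, the size of such a step cannot be read off. Mirror images often behave quite differently in an assay of this kind, so a change of some size in either direction is plausible. As an estimate, compound 3 is expected to give about 50%, within 10% to 95%, which corresponds to an expected step of a number 31 percentage points higher from compound 1 to compound 3 (beyond the scatter).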

Compound 3, largest response reached (reported as percent of maximum), in percent of the reference or control that the assay uses: 53%
Compound 3: middle estimate off by 3 percentage points, on the low side, and the stated range covers the measured number.
By their numbers in this assay, from the lowest: compound 1; then compound 3; then compound 2.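

Inverting both stereocentres gives a number 34 percentage points higher from compound 1 to compound 3 (beyond the scatter) in this assay. Within the data shown here, this is the first change here that can be read on its own, since the earlier numbers could only be set side by side. The step can be tied to the spatial arrangement of the molecule alone, because nothing else separates the pair: the fact that compounds 1 and 3 differ only in the configuration as drawn

The compounds shown leave open whether a mirror-image pair carrying an ethyl group in place of the methyl group, or an amide in place of the aromatic ring, would show a gap of similar size or the same direction. They also leave open how this difference in largest response relates to the concentration each mirror image needs to reach it, since a single read-out of maximal response says nothing about that.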